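The compounds below may be only part of what the source reports. "The series", "measured", "known", "first", "only" and "open" are said of these compounds alone.

Measured so far in an assay on isolated protein for inhibition of Aromatase (Homo sapiens), read by fluorescence, using NADPH, with a stated time of 30 min, tested at 50 uM; a lower number here means less inhibition, a higher number more inhibition at the concentration tested (going by the name of the read-out):
compound 1 `C#CCn1c(-c2ccccc2)cc2ccccc21` gives 26.3%
compound 2 `Clc1ccc2cc(-c3ccccc3)[nH]c2c1` gives 13.6%

Compound 2 stands lowest of the two numbers in this assay; the nearest value belongs to compound 1, which sits higher by an amount beyond the usual scatter of repeated measurements. Compound 3 `Cc1ccc2cc(-c3ccccc3)[nH]c2c1` has not yet been measured. It differs from compound 2 at one place: methyl in place of chloro on an aromatic carbon. Among the measured compounds shown here, no step between two measured compounds that differ in only one place is available, so the effect of this exchange cannot be read from the numbers at hand. Because compound 2 gives 13.6% and the change is a swap of one small group for another, the account expects a step of a number 1.6 percentage points lower from compound 2 to compound 3 (within the scatter) that stays within the scatter, without a clear direction. The estimate for compound 3 in this assay is therefore 12%, with a range from 2% to 24%.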

Compound 3, a percentage reported as inhibition, at one concentration (the size of the read-out at that concentration, not a potency): 32.4%
The estimate for compound 3 lay 20.4 percentage points below the measured number; measured number above the stated range.
By their numbers in this assay, from the lowest: compound 2; then compounds 1 and 3 (each within the scatter of the next).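

In this assay, the exchange of chloro for methyl on this aromatic carbon appears as a number 18.8 percentage points higher from compound 2 to compound 3 (beyond the scatter), the only step shown between two measured compounds that differ in one place. This position is therefore not indifferent to which group it carries, even though chloro and methyl each count one heavy atom and neither adds a hydrogen-bond donor or acceptor. No measurement at hand bears on why the two groups differ.

The compounds shown leave open whether the higher number persists with a longer chain such as ethyl, or with a methoxy group or an amine on the same carbon. They also leave open whether fluoro or bromo would follow chloro, and whether methyl on another carbon of this ring would give a similar step.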